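Ethylsulfanyl analogue of the nitro compound: expected potency

The source may report more compounds than this note shows. Statements on the series, on what has been measured and on what is new or still open speak of the compounds shown alone.

Measured compounds:
compound 1 `CCN1C(=O)N(CC)C2C1N=C(SC)N2/N=C/C=C/c1ccccc1` — 151000 nM
compound 3 `CCN1C(=O)N(CC)C2C1N=C(SC)N2/N=C/C=C/c1ccccc1OC` — 145000 nM
compound 2 `CCN1C(=O)N(CC)C2C1N=C(SC)N2/N=C/C=C/c1ccccc1[N+](=O)[O-]` — "not determined" (no result reported)

In an ADME assay on HEK293 cells (Homo sapiens) for inhibition, read by MTT assay, with a stated time of 72 h (on this read-out lower numbers stand for stronger inhibition and higher numbers for weaker inhibition), compound 1 gives 151000 nM, and in this assay compound 3 gives 145000 nM. For the measured compounds named here, the one step seen so far, a 1.0-fold lower number from compound 1 to compound 3 (0.02 log units; within the scatter), changes nothing beyond the scatter. In this assay compound 2 is reported as "not determined" (no result reported); where it stands is not known from the data, so the only anchors for the series are the values of compound 1 and compound 3, which agree with each other.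

Compound 4 `CCSC1=NC2C(N(CC)C(=O)N2CC)N1/N=C/C=C/c1ccccc1[N+](=O)[O-]` differs from compound 2 by methyl in place of hydrogen on a saturated chain carbon bound to a sulfur. Going by the values given here, no measured step touches the methylsulfanyl group, and the single step that has been measured concerns the aromatic ring rather than the chain bound to sulfur; it does not bear on this change. Nothing in the data therefore points to a step in either direction in this assay beyond the scatter, and the expectation can only be that compound 4 falls where the two measured compounds fall.

Compound 4 is expected to give about 150000 nM in this assay, with a range from 50000 nM to 450000 nM. This expectation rests on compound 1 at 151000 nM and compound 3 at 145000 nM, with the missing value of compound 2 leaving the effect of the nitro group unknown.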

Compound 4, half-maximal inhibitory concentration: 221000 nM
Estimate against measurement, compound 4: 1.5-fold (0.17 log units) below, and the stated range covers the measured number.
By their numbers in this assay, from the lowest: compounds 3, 1 and 4 (each within the scatter of the next).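

In this assay, for the compounds shown here, compound 2 has no single number to set against compound 4 at 221000 nM, so no step between them can be read. The compounds shown leave open what methylsulfanyl to ethylsulfanyl does on its own in this assay, with the nitro group held constant. No supporting evidence bears on this result.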